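From an Amide to a Sulfonamide on the Shared Core

This account rests on a few compounds, and the source may have more. Where it says the series, first, only, none or still open, it means among the compounds named here.

Compound 2 `CN(C(=O)c1ccco1)c1ccc2[nH]c(-c3n[nH]c4ccccc34)cc2n1` carries a (furan-2-yl)carbonyl group on the ring nitrogen of the shared core. Among the compounds with values here, in a functional assay on KB cells (Homo sapiens) for antiproliferative activity, read by MTT assay, with a stated time of 72 h (a higher number here means a weaker inhibitor, a lower number a stronger inhibitor), compound 2 gives 19400 nM, the higher of the two numbers recorded, though it sits within the scatter of its only neighbour: compound 1 `COc1ccc(C(=O)N(C)c2ccc3[nH]c(-c4n[nH]c5ccccc45)cc3n2)cc1`, which in this assay gives 12900 nM. Within the data shown here, the single measured step, a 1.5-fold higher number from compound 1 to compound 2 (0.18 log units; within the scatter), exchanges one acyl group for another without moving the number beyond the scatter.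

Compound 3 `Cc1ccc(S(=O)(=O)N(C)c2ccc3[nH]c(-c4n[nH]c5ccccc45)cc3n2)cc1` differs from compound 2 by (4-methylphenyl)sulfonyl in place of (furan-2-yl)carbonyl on a nitrogen on an aromatic ring. Among the measured compounds shown here, no measured step bears directly on this change: the only step on record swaps aryl groups on a carbonyl carbon, whereas here the carbonyl itself gives way to a sulfonyl and the aromatic ring changes as well. With the two measured compounds lying within the scatter of each other, there is no trend to extrapolate. Compound 3 is therefore expected to land near compound 2, with a step of a 1.0-fold higher number from compound 2 to compound 3 (0.01 log units; within the scatter) in this assay and an estimated value of 20000 nM, between 6000 nM and 70000 nM.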

Compound 3, half-maximal inhibitory concentration: 9500 nM
Beside the measured number, compound 3's estimate is 2.1-fold (0.32 log units) above it, within the range that was stated.
By their numbers in this assay, from the lowest: compounds 3, 1 and 2 (each within the scatter of the next, the first and the last beyond it).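

On the nitrogen on an aromatic ring of the shared core, a sulfonyl group can take the place of a carbonyl with the number staying in the same range. In this assay, within the data shown here, the exchange of (furan-2-yl)carbonyl for (4-methylphenyl)sulfonyl gives a 2.0-fold lower number from compound 2 to compound 3 (0.31 log units; beyond the scatter) and is the first step in this set to pass the scatter, though only modestly. Against the other acyl group the same sulfonyl gives a 1.4-fold lower number from compound 1 to compound 3 (0.13 log units; within the scatter) and leaves compound 1 and compound 3 indistinguishable, so the sulfonyl group shows no consistent gain over the carbonyl compounds. No measurement at hand offers an explanation for the step from the furan compound.

The step to compound 3 replaces the carbonyl and the aromatic ring at once, so the compounds shown leave open how much of it belongs to the sulfonyl and how much to the ring. Also open, going by these compounds, is how a sulfonyl carrying furan-2-yl would read, and how a simple methylsulfonyl group or an amine on the aromatic ring would fare on this nitrogen.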